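From Trifluoromethyl to Chloro: Expecting a Similar Readout

The source may hold more compounds than are shown below. What is called first, only, known or untested is meant among the compounds shown, and "the series" means these compounds.

Compound 1 `COc1cc(Cl)cc(-c2nn(-c3cccc(NC(=O)Nc4ccc(Cl)c(C(F)(F)F)c4)c3)cc2-c2ccncc2)c1` and compound 2 `COc1cc(Cl)cc(-c2nn(-c3cccc(NC(=O)c4cc(C(F)(F)F)cc(C(F)(F)F)c4)c3)cc2-c2ccncc2)c1` share a common core and were both tested in a functional assay on MDA-MB-468 cells (Homo sapiens) for inhibition, read by sulforhodamine B assay, with a stated time of 48 h, tested at 10 uM; on this read-out lower numbers stand for a stronger effect and higher numbers for a weaker effect at the one concentration tested. In this assay compound 1 gives -14.4%, the lowest of the two numbers, while compound 2 gives 46.5%, a gap well beyond the usual scatter. Compound 3 `COc1cc(Cl)cc(-c2nn(-c3cccc(NC(=O)Nc4ccc(Cl)c(Cl)c4)c3)cc2-c2ccncc2)c1` differs from compound 1 in a single place: chloro in place of trifluoromethyl on an aromatic carbon. Among the compounds with values here, no measured pair shows the effect of this change, so the expected step is small, a number 9.4 percentage points higher from compound 1 to compound 3 (within the scatter), likely within the scatter. Compound 3 is therefore estimated at -5%, within a range from -25% to 20%.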

Compound 3, a percentage reported as activity, at one concentration (the size of the read-out at that concentration, not a potency): 0.72%
Compound 3: the middle estimate sits 5.7 percentage points below what was measured; the range from low to high includes it.
By their numbers in this assay, from the lowest: compound 1; then compound 3; then compound 2.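

Trifluoromethyl to chloro on this aromatic carbon can now be read on its own: in this assay the change gives a number 15.1 percentage points higher from compound 1 to compound 3 (beyond the scatter) on the way to a weaker effect. The position therefore responds to this exchange, although the step is modest and replacing four heavy atoms with one does not remove the effect. No measurement here explains the step. From the compounds shown here alone, it remains open how a methyl group, a nitrile or an amine on this same carbon would compare. Whether the exchange gives a similar step on another core is also unknown.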